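The compounds below may be only part of what the source reports. "The series", "measured", "known", "first", "only" and "open" are said of these compounds alone.

Measured so far in a physicochemical assay, read by spectrophotometry, with a stated time of 240 min, tested at 100 uM; a lower number here means a weaker effect, a higher number a stronger effect of the compound at the concentration tested:
- compound 1, `O=C(O)Cn1c(=O)c(Oc2ccc(O)cc2)nc2ccccc21`: 21.3%
- compound 2, `O=C(O)Cn1c(=O)c(Oc2cc(O)cc(O)c2)nc2ccccc21`: 67.4%
- compound 3, `O=C(O)Cn1c(=O)c(Oc2cc(O)cc(O)c2)nc2cc(Cl)ccc21`: 56.5%

Compound 2 gives the highest of the three numbers. The nearest is compound 3, reached by a number 10.9 percentage points lower from compound 2 to compound 3 (beyond the scatter). The furthest is compound 1, from which compound 2 is separated by a number 46.1 percentage points higher from compound 1 to compound 2 (beyond the scatter). Both steps lie beyond the scatter, so compound 2 is the strongest of the measured set in this assay.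

Compound 4, `O=C(O)Cn1c(=O)c(Oc2cc(O)cc(O)c2)nc2ccc(F)cc21`, is not yet measured. It differs from compound 2 in one place: fluoro in place of hydrogen on an aromatic carbon.

Going by the values given here, only one measured step bears on this change, the halogen-for-hydrogen exchange on the fused ring from compound 2 to compound 3, which was modest and downward, a number 10.9 percentage points lower from compound 2 to compound 3 (beyond the scatter). Fluoro appears nowhere else in the series, and the new substituent sits at a different carbon of the fused ring than the chloro of compound 3, so that step is a rough guide only. A small downward step, or none beyond the scatter, is expected in this assay: a number 7.4 percentage points lower from compound 2 to compound 4 (within the scatter).

Compound 4 is therefore estimated at 60%, with a range from 45% to 75%.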

Compound 4, a percentage reported as activity, at one concentration (the size of the read-out at that concentration, not a potency): 38.2%
Estimate against measurement, compound 4: 21.8 percentage points above; the whole stated range lies above it.
By their numbers in this assay, from the lowest: compound 1; then compound 4; then compound 3; then compound 2.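

In this assay, fluoro on this aromatic carbon of the fused system, meta to a fused ring and para to a fused ring, does not pass as a near-silent replacement of hydrogen: the change gives a number 29.2 percentage points lower from compound 2 to compound 4 (beyond the scatter). This single heavy atom costs clearly more than the chloro on another carbon of the fused system, which gives a number 10.9 percentage points lower from compound 2 to compound 3 (beyond the scatter), so the size of the loss on halogen substitution is not constant across these two changes, although both go downward from compound 2 and neither compound goes against that direction. No measurement shown bears on the reason for the larger drop, and the two steps alone offer no explanation for it.

Still open, going by these compounds, is whether the larger loss belongs to fluoro itself or to this carbon, a question that chloro on this same carbon, or fluoro on the carbon carrying chloro in compound 3, would settle. Equally open, on these data alone, is whether any replacement of hydrogen here is tolerated, for instance a methoxy group or an amine on this carbon.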